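The compounds below may be only part of what the source reports. "The series", "measured", "known", "first", "only" and "open" are said of these compounds alone.

Among the compounds with values here, compound 2 `O=c1nc(-c2ccccc2)c2cc(-c3ccccc3F)ccc2[nH]1` gives 55800 nM in an ADME assay on L6 cells (Rattus norvegicus) for cytotoxicity, read by fluorescence and resazurin assay, with a stated time of 72 h (a lower number here means that less compound is needed, a higher number that more compound is needed for the effect), the only number in this pair. Compound 1 `O=c1nc(-c2ccccc2)c2cc(-c3ccccc3)ccc2[nH]1` reaches only the limit of the assay, > 50000 nM. The step that the limit leaves unreadable from compound 1 to compound 2 is therefore unreadable, as the limit of > 50000 nM in this assay, at which 1 of the 2 values shown sits, shows. Compound 3 `O=c1nc(-c2ccccc2)c2cc(-c3cccc(F)c3)ccc2[nH]1` differs from compound 2 by 3-fluorophenyl in place of 2-fluorophenyl on an aromatic carbon. Within the data shown here, no measured step bears on moving the fluorine within the phenyl ring, so no shift beyond the scatter is expected, and the estimate for compound 3 in this assay is 55000 nM, within 25000 nM to 120000 nM. The expected step of a 1.0-fold lower number from compound 2 to compound 3 (0.01 log units; within the scatter) thus stays within the scatter.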

Compound 3, half-maximal effective concentration: 23000 nM
Beside the measured number, compound 3's estimate is 2.4-fold (0.38 log units) above it; measured number below the stated range.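

Where the fluorine sits on this phenyl ring matters in this assay, since an exchange of 2-fluorophenyl for 3-fluorophenyl, with the same atoms, gives a 2.4-fold lower number from compound 2 to compound 3 (0.38 log units; beyond the scatter). Fluoro in place of hydrogen also now has a readable direction, with an at least 2.1-fold lower number from compound 1 to compound 3 (0.33 log units; beyond the scatter). Compound 1 stands at a limit, so that step gives only a bound: the limit of > 50000 nM in this assay, at which 1 of the 3 values shown sits.

As far as these compounds go, what remains open is how 4-fluorophenyl would compare at this place. From the compounds shown here alone, it is also open whether a group other than fluoro, such as an amine or a carboxylic acid on this phenyl ring, would move the number further.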